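Replacing 3-chlorophenyl with 4-hydroxyphenyl on an amide-type nitrogen

The compounds below may be only part of what the source reports. "The series", "measured", "known", "first", "only" and "open" are said of these compounds alone.

Of the compounds shown here, three built on a shared core have numbers so far. In a functional assay on NCI-H1299 cells (Homo sapiens) for inhibition, read by CCK-8 assay, with a stated time of 72 h, tested at 1 uM (a higher number here means more inhibition of growth at the concentration tested, a lower number less inhibition of growth), compound 2 (`CN(C)C(=O)c1cc2cnc(Nc3ccc(NC(=O)C4(C(=O)Nc5cccc(Cl)c5)CC4)cc3)nc2n1C1CCCC1`) gives 47.9% at the tested concentration. Compound 3 (`CN(C)C(=O)c1cc2cnc(Nc3ccc(NC(=O)C4(C(=O)Nc5ccc(F)cc5)CC4)cc3F)nc2n1C1CCCC1`) gives 52.3% in the same test, which lies within the scatter of compound 2. Compound 1 (`CN(C)C(=O)c1cc2cnc(Nc3ccc(NC(=O)C4(C(=O)Nc5cccc(O)c5)CC4)cc3)nc2n1C1CCCC1`) gives 77.5% and stands beyond the scatter above compound 2.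

The next compound to be read is compound 4 (`CN(C)C(=O)c1cc2cnc(Nc3ccc(NC(=O)C4(C(=O)Nc5ccc(O)cc5)CC4)cc3)nc2n1C1CCCC1`), with 4-hydroxyphenyl in place of 3-chlorophenyl on an amide-type nitrogen. Going by the values given here, one measured step bears on this change: chloro in place of hydroxy on an aromatic carbon (a number 29.6 percentage points lower from compound 1 to compound 2 (beyond the scatter)), a modest step beyond the scatter. Read in reverse, it suggests that a hydroxy ring goes with a higher number than a chloro ring. However, the hydroxy of compound 4 does not sit where it sits in compound 1, and no measured step tests that difference. Among the compounds with values here, compound 3 differs from compound 2 in more than one place and offers no clean step.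

The step expected in this assay is therefore upward and is estimated as (a number 20.1 percentage points higher from compound 2 to compound 4 (beyond the scatter)) with wide uncertainty. For compound 4 the estimated value is 68% with an expected range from 48% to 85% in this test.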

Compound 4, percent growth inhibition at one concentration: 87.4%
Estimate against measurement, compound 4: 19.4 percentage points below; the whole stated range lies below it.
By their numbers in this assay, from the lowest: compounds 2 and 3 (each within the scatter of the next); then compounds 1 and 4 (each within the scatter of the next).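

In this assay, the exchange of 3-chlorophenyl for 4-hydroxyphenyl on the amide-type nitrogen gives a number 39.5 percentage points higher from compound 2 to compound 4 (beyond the scatter) and is a large step, so this position responds strongly to what the aromatic ring carries. That exchange alters both the group on the ring and its place, and the comparison of the two hydroxy compounds helps to separate these: a number 9.9 percentage points higher from compound 1 to compound 4 (within the scatter) is the step from 3-hydroxyphenyl to 4-hydroxyphenyl, so the two placements of the hydroxy group cannot be told apart in this test, and both compounds stand well clear of compound 2. Nothing given here explains why the number moves with this change.

The compounds shown leave chloro and hydroxy compared at only one place on the ring, so a 4-chlorophenyl group on the same nitrogen would be needed to test the group apart from its place. As far as these compounds go, it also remains open whether a 4-methoxyphenyl or a 4-aminophenyl group there would match the two hydroxy compounds or stay closer to compound 2, and whether the reading in this cell test would carry over to other cell lines.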